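A few compounds are considered here, and "the series" means these few. Any claim that something is new, unique, unknown or untested is made for them only; others in the source may bear on it.

In a physicochemical assay for pharmacokinetics, read by spectrophotometry, in phosphate buffer, with a stated time of 5 min, tested at 40 uM, in the presence of a further agent that is not named here (a lower number here means that the compound disappears faster, a higher number that the compound lasts longer), compound 1 `CC(C)Cc1ccc(C(C)C(=O)Oc2ccc(-c3cc(=S)ss3)cc2)cc1` gives 0.0233 h, compound 2 `O=C(/C=C/c1ccccc1)Oc1ccc(-c2cc(=S)ss2)cc1` gives 0.0317 h, and compound 3 `CC(C(=O)Oc1ccc(-c2cc(=S)ss2)cc1)c1ccc(C(=O)c2ccccc2)cc1` gives 0.0567 h. Compound 2 sits close to both of the others: its gap to compound 1 and its gap to compound 3 each fall within the scatter, so the three numbers establish no order among themselves. For the measured compounds named here, the one step in which two measured compounds differ in a single place is a 2.4-fold higher number from compound 1 to compound 3 (0.39 log units; beyond the scatter), a change on the acyl side of the shared core.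

Compound 4 `NC(=S)c1ccc(OC(=O)/C=C/c2ccccc2)cc1` keeps the acyl side of compound 2 and changes the other end: a group of 3 heavy atoms (1 carbon, 1 nitrogen, 1 sulfur; no ring) in place of a group of 6 heavy atoms (3 carbon, 3 sulfur; one five-membered aromatic ring with 2 hetero atoms), on an aromatic carbon. Going by the values given here, no measured pair exchanges this group, so the step from compound 1 to compound 3 does not bear on it directly; it shows only that a change elsewhere in the shared core moved this assay modestly. Without a comparable precedent, the step of a 1.1-fold higher number from compound 2 to compound 4 (0.04 log units; within the scatter) is expected to stay within the scatter, and the range is widened to reflect the absence of a direct comparison. Compound 4 is therefore estimated at 0.035 h in this assay, with a range from 0.012 h to 0.1 h.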

Compound 4, half-life: 0.0733 h
Compound 4: the middle estimate sits 2.1-fold (0.32 log units) below what was measured; measured number inside the range.
By their numbers in this assay, from the lowest: compounds 1, 2, 3 and 4 (each within the scatter of the next, the first and the last beyond it).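

In this assay, for the compounds shown here, the exchange on the aromatic carbon, para to a large group, gives a 2.3-fold higher number from compound 2 to compound 4 (0.36 log units; beyond the scatter) and is the first step read at this end of the molecule. The earlier single-place step a 2.4-fold higher number from compound 1 to compound 3 (0.39 log units; beyond the scatter) lay on the acyl side, whereas this result shows that the half-life also responds to the group at the other end of the shared core. It also shows that, with the acyl side of compound 2 held fixed, the five-membered aromatic ring with 2 hetero atoms can give way to a group of 3 heavy atoms with no ring without any shortening of the half-life, though no measurement given here explains the step.

On these data alone, the exchange is read on a single acyl side, so it remains open whether it would run the same way on the acyl side of compound 1 or compound 3. Also open, as far as these compounds go, is how the half-life would respond at this position to a nitrile, or to an amide with oxygen in place of the sulfur of the entering group.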